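Ring size at the amide cap: oxetane to oxolane

The source may hold more compounds than are shown below. What is called first, only, known or untested is meant among the compounds shown, and "the series" means these compounds.

Measured compounds:
compound 1 `CC(=O)NCc1cccc(Cn2nc(NS(=O)(=O)c3ccc(Cl)s3)c3c(C(C)(C)O)cccc32)c1` with 100 nM
compound 2 `COc1cccc2c1c(NS(=O)(=O)c1ccc(Cl)s1)nn2Cc1cccc(CNC(=O)C2COC2)c1` with 20 nM
compound 3 `COc1cccc2c1c(NS(=O)(=O)c1ccc(Cl)s1)nn2Cc1cccc(CNC(=O)C2CCO2)c1` with 31.6 nM

In a functional assay on CHO cells for antagonist activity at C-C chemokine receptor type 4 (Homo sapiens), read by GTPgammaS binding (on this read-out higher numbers stand for weaker inhibition and lower numbers for stronger inhibition), compound 3 gives 31.6 nM, the second highest of the three numbers. Its nearest neighbour is compound 2, which in this assay gives 20 nM; the furthest is compound 1, which in this assay gives 100 nM, a gap that lies beyond the scatter, though compound 1 differs from compound 3 in more than one place and no single step can be read from it.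

The next compound is compound 4 `COc1cccc2c1c(NS(=O)(=O)c1ccc(Cl)s1)nn2Cc1cccc(CNC(=O)C2CCCO2)c1`, which has not yet been tested. It differs from compound 3 in one place: oxolan-2-yl in place of oxetan-2-yl on a carbonyl carbon. Within the data shown here, the only measured step that touches this region of the molecule is a 1.6-fold higher number from compound 2 to compound 3 (0.20 log units; within the scatter), a change of attachment point within the same four-membered ring, which stayed within the scatter. Among the measured compounds shown here, nothing measured so far speaks to enlarging the ring by one carbon. On that basis the expectation for compound 4 in this assay is no step beyond the scatter, a 1.0-fold higher number from compound 3 to compound 4 (0.01 log units; within the scatter), and the estimated value is 32 nM, within a range of 12 nM to 85 nM.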

Compound 4, half-maximal inhibitory concentration: 39.8 nM
For compound 4 the middle estimate is 1.2-fold (0.09 log units) below the measured one; low and high end bracket the measured number.
By their numbers in this assay, from the lowest: compounds 2, 3 and 4 (each within the scatter of the next); then compound 1.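

Going from the four-membered to the five-membered ring on the carbonyl carbon gives, in this assay, a 1.3-fold higher number from compound 3 to compound 4 (0.10 log units; within the scatter), so the first measured change in ring size at this amide cap stays within the scatter. Set against the oxetan-3-yl cap, the oxolan-2-yl cap gives a 2.0-fold higher number from compound 2 to compound 4 (0.30 log units; within the scatter), also within the scatter, and the three caps on this shared core cannot be separated in this read-out. No supporting data bear on why these caps read alike.

Still open, as far as these compounds go, is whether this holds for a larger ring such as oxan-2-yl, or for a ring nitrogen in place of the oxygen, as in pyrrolidin-2-yl. Also open, from the compounds shown here alone, is whether the ring oxygen matters at all, a question that a cyclopentyl cap would address.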